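Para-bromo in place of tert-butyl on the sulfonamide aniline

The compounds below may be only part of what the source reports. "The series", "measured", "known", "first", "only" and "open" are said of these compounds alone.

Measured so far:
compound 1 `O=C1NCCN1c1ccc(S(=O)(=O)Nc2ccc(C3CCCCC3)cc2)cc1`: > 1000 nM
compound 2 `Cc1cccc(NS(=O)(=O)c2ccc(N3CCNC3=O)cc2)c1`: 190 nM
compound 3 `CC(C)(C)c1ccc(NS(=O)(=O)c2ccc(N3CCNC3=O)cc2)cc1`: > 1000 nM

In a functional assay on MCF7 cells (Homo sapiens) for antiproliferative activity, read by sulforhodamine B assay, with a stated time of 48 h (on this read-out lower numbers stand for stronger inhibition and higher numbers for weaker inhibition), compound 3 gives only the assay limit, > 1000 nM, not a number. Compound 1 likewise sits at the limit, > 1000 nM. Among the compounds with values here, compound 2, carrying a methyl, is the only compound with a real number, 190 nM. Within the data shown here, the single measured step, a step that the two limits leave unreadable from compound 1 to compound 3, cannot be read, as the limit of > 1000 nM in this assay, at which 2 of the 3 values shown sit, states. Compound 4 `O=C1NCCN1c1ccc(S(=O)(=O)Nc2ccc(Br)cc2)cc1` is obtained by the change (bromo in place of tert-butyl on an aromatic carbon). Among the measured compounds shown here, no measured step bears directly on a bromo group; the only guide is that the two compounds with cyclohexyl and tert-butyl stand at the limit while the methyl-bearing compound 2 does not. On that basis compound 4 is expected to move off the limit toward the value of compound 2, with wide uncertainty, and the expected step is an at least 2.2-fold lower number from compound 3 to compound 4 (0.34 log units; beyond the scatter). For compound 4 the estimate is 450 nM, between 120 nM and 2000 nM.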

Compound 4, half-maximal inhibitory concentration: 240 nM
Compound 4: middle estimate off by 1.9-fold (0.27 log units), on the high side, within the range that was stated.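

In this assay, a group at this place on the sulfonamide aniline does not by itself hold a compound at the limit: bromo in place of tert-butyl gives an at least 4.1-fold lower number from compound 3 to compound 4 (0.61 log units; beyond the scatter), and bromo in place of cyclohexyl gives an at least 4.1-fold lower number from compound 1 to compound 4 (0.61 log units; beyond the scatter). Both steps are bounds and not true sizes: the limit of > 1000 nM in this assay, at which 2 of the 4 values shown sit. The change of 3-methylphenyl to 4-bromophenyl on the sulfonamide nitrogen gives a 1.3-fold higher number from compound 2 to compound 4 (0.10 log units; within the scatter), so these two aryl groups cannot be ordered on this read-out.

Compound 2 and compound 4 differ in both the group and its place on the ring, so the effect of each remains unseparated. On these data alone, how an amine, a carboxylic acid or a longer chain would stand at this place also remains open.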